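The source may hold more compounds than are shown below. What is called first, only, known or untested is meant among the compounds shown, and "the series" means these compounds.

Among the measured compounds shown here, compound 1 `S=c1oc(-c2ccc3c(c2)OCCO3)nn1CN1CCN(c2ccc(Cl)cc2)CC1` carries a 4-chlorophenyl on an amine nitrogen in a ring, and its two measured neighbours vary only that aryl group. In a functional assay on BGC-823 cells (Homo sapiens) for antiproliferative activity, read by MTT assay, with a stated time of 48 h (a lower number here means a stronger inhibitor, a higher number a weaker inhibitor), compound 1 gives > 50000 nM, a limit of the assay rather than a number. Compound 2 `COc1ccccc1N1CCN(Cn2nc(-c3ccc4c(c3)OCCO4)oc2=S)CC1` gives 19500 nM in this assay. Compound 3 `COc1cccc(N2CCN(Cn3nc(-c4ccc5c(c4)OCCO5)oc3=S)CC2)c1` gives > 50000 nM in this assay, again a limit. The steps among them show how much the aryl group matters: an at least 2.5-fold lower number from compound 1 to compound 2 (0.40 log units; beyond the scatter), an at least 2.5-fold higher number from compound 2 to compound 3 (0.40 log units; beyond the scatter), and a step that the two limits leave unreadable from compound 1 to compound 3. Compound 1 thus stands at the limit of > 50000 nM in this assay, at which 2 of the 3 values shown sit, with no number to rank it against.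

Compound 4 `S=c1oc(-c2ccc3c(c2)OCCO3)nn1CN1CCN(c2cccc(Cl)c2Cl)CC1` is not yet measured. It differs from compound 1 by 2,3-dichlorophenyl in place of 4-chlorophenyl on an amine nitrogen in a ring. For the measured compounds named here, no measured step exchanges one chlorophenyl for another; the nearest evidence is the pair of methoxyphenyl steps, each beyond the scatter and in opposite directions, which shows that the aryl group can shift this assay either way but gives no direction for a second chlorine. Compound 4 is therefore expected to remain weak, at an estimated 45000 nM with a range of 15000 nM to 150000 nM. The step of an at least 1.1-fold lower number from compound 1 to compound 4 (0.04 log units; that floor lies within the scatter) is expected to be small and uncertain.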

Compound 4, half-maximal inhibitory concentration: 22600 nM
Estimate against measurement, compound 4: 2.0-fold (0.30 log units) above; the range from low to high includes it.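

In this assay, the 2,3-dichlorophenyl group gives a readable number where the 4-chlorophenyl and 3-methoxyphenyl groups do not, with an at least 2.2-fold lower number from compound 1 to compound 4 (0.34 log units; beyond the scatter) and an at least 2.2-fold lower number from compound 3 to compound 4 (0.34 log units; beyond the scatter). Among the compounds shown here, this is the first evidence on a chlorinated aryl group at this place, on an amine nitrogen in a ring, and it shows that chlorine on this aryl group does not by itself hold a compound at the limit. There is also a 1.2-fold higher number from compound 2 to compound 4 (0.06 log units; within the scatter), so the 2-methoxyphenyl and 2,3-dichlorophenyl groups cannot be told apart here, while the two other aryl groups stay at a limit of the assay: the limit of > 50000 nM in this assay, at which 2 of the 4 values shown sit.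

The change both adds a chlorine and alters where chlorine stands on the aryl group, and a 2-chlorophenyl or a 3-chlorophenyl group would be needed to separate these two parts of it. Also open, going by these compounds, is whether a plain phenyl, or an aryl group bearing an amine or a carboxylic acid, would give a lower number in this assay than the level shared by compound 2 and compound 4.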